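The source may report more compounds than this note shows. Statements on the series, on what has been measured and on what is new or still open speak of the compounds shown alone.

Working notes on a small series run in a functional assay on cells (blood, Homo sapiens) for inhibition, read by chemiluminescence, with a stated time of 30 min; on this read-out lower numbers stand for stronger inhibition and higher numbers for weaker inhibition. Compound 1 `CCCCSC(=S)C1=C(Nc2ccc(Cl)cc2Cl)CC(C)(C)CC1=O` is the parent; compound 2 `CCCCCCCCCCCSC(=S)C1=C(Nc2ccc(Cl)cc2Cl)CC(C)(C)CC1=O` and compound 3 `CCCCSC(=S)C1=C(Nc2ccc(Cl)cc2)CC(C)(C)CC1=O` each differ from it in one place. In this assay compound 1 reaches only the assay limit, > 100 ug/mL. Compound 2 likewise returns a limit in this assay, > 100 ug/mL. Compound 3 also stands at a limit in this assay, > 100 ug/mL, so its position on the numbers is known only as a bound. Accordingly a step that the two limits leave unreadable from compound 1 to compound 2, and a step that the two limits leave unreadable from compound 1 to compound 3; the limit of > 100 ug/mL in this assay, at which 3 of the 3 values shown sit, describes the whole measured set. Compound 4 `CCCCCCCCCCCSC(=S)C1=C(Nc2ccc(Cl)cc2)CC(C)(C)CC1=O` differs from compound 3 by heptyl in place of hydrogen on a saturated chain carbon, four bonds along the chain from a sulfur. The same change made elsewhere in the series left both values at the limit, with no readable size. Compound 4 is therefore expected to stay at the limit too, a step that the limit leaves unreadable from compound 3 to compound 4, estimated at 150 ug/mL within 100 ug/mL to 400 ug/mL.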

Compound 4, half-maximal inhibitory concentration: > 100 ug/mL
Compound 4: no number, only a limit (the forecaster's own chance of this, stated with the estimate: 90%); the middle value is on the limit's open side.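

Compound 4 gives no readable step against compound 3 or compound 2, because the values all rest at one limit: the limit of > 100 ug/mL in this assay, at which 4 of the 4 values shown sit.

The compounds shown leave open whether heptyl or chloro changes inhibition at all, and by how much.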